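Butyl in Place of Tert-Butyl on Compound 1

The source may hold more compounds than are shown below. What is called first, only, known or untested is meant among the compounds shown, and "the series" means these compounds.

In an ADME assay on Vero cells (Chlorocebus sabaeus) for cytotoxicity (on this read-out lower numbers stand for higher toxicity in this test and higher numbers for lower toxicity in this test), compound 1 `CC(=O)OC[C@H]1O[C@@H](n2cc(-c3cc(-c4ccc(C(C)(C)C)cc4)no3)c(=O)[nH]c2=O)C[C@@H]1OC(C)=O` gives 3000 nM. This is level with compound 2 `CC(C)(C)c1ccc(-c2cc(-c3cn([C@H]4C[C@H](O)[C@@H](CO)O4)c(=O)[nH]c3=O)on2)cc1` at 3000 nM and compound 3 `CCCCCCCCc1cc(-c2cn([C@H]3C[C@H](O)[C@@H](CO)O3)c(=O)[nH]c2=O)on1` at 3000 nM. Compound 4 `CCCCc1ccc(-c2cc(-c3cn([C@H]4C[C@H](OC(C)=O)[C@@H](COC(C)=O)O4)c(=O)[nH]c3=O)on2)cc1` keeps the core of compound 1 and has butyl in place of tert-butyl on an aromatic carbon. Among the compounds with values here, one measured step bears on this change, with octyl in place of 4-(tert-butyl)phenyl on an aromatic carbon: no change at the digits printed from compound 2 to compound 3 (within the scatter). That step stayed within the scatter, so no step beyond the scatter is expected in this assay for the new swap. The expected step is no change at the digits printed from compound 1 to compound 4 (within the scatter). Compound 4 is estimated at 3000 nM, with an expected range of 1500 nM to 6000 nM.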

Compound 4, half-maximal cytotoxic concentration: 3000 nM
The estimate for compound 4 equals the measured number at the digits printed; low and high end bracket the measured number.
By their numbers in this assay, from the lowest: compounds 1, 2, 3 and 4 (each within the scatter of the next).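

Rearranging the same four carbons, from tert-butyl to butyl, on the aromatic carbon para to a large group gives no change at the digits printed from compound 1 to compound 4 (within the scatter) in this assay. Unlike the earlier step, which replaced the whole 4-(tert-butyl)phenyl group, this one alters only the small group on that ring, and the shape of that group leaves the read-out unmoved in this pair. No measurement shown here accounts for this result. Going by these compounds, both groups at this position contain only carbon and hydrogen, so the effect of an amine or a carboxylic acid there remains open.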